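The compounds below may be only part of what the source reports. "The series", "measured", "known", "first", "only" and "open" are said of these compounds alone.

Measured compounds in this series:
- compound 1 `O=C1CC(c2ccccc2)CN1c1cnn2c1CN(C(=O)Nc1cc(F)c(F)c(F)c1)C(C1CC1)C2` — 12800 nM
- compound 2 `C[C@H]1Cn2ncc(N3CC(c4ccccc4)CC3=O)c2CN1S(=O)(=O)Nc1cc(F)c(F)c(F)c1` — > 2000 nM, a limit of the assay
- compound 3 `O=C1CC(c2ccccc2)CN1c1cnn2c1CN(C(=O)Nc1cc(F)c(F)c(F)c1)C(Cc1ccccc1)C2` — > 2000 nM, a limit of the assay

In a toxicity assay on HepG2 2.2.15 cells (Homo sapiens) for cytotoxicity, read by CellTiter-Glo (on this read-out lower numbers stand for higher toxicity in this test and higher numbers for lower toxicity in this test), compound 1 gives 12800 nM, the only number shown in the series. The two further values, those for compound 2 and compound 3, are limits of the assay rather than numbers. For compound 2 the result is a limit. For compound 3 the result is likewise a limit. Going by the values given here, the single one-place step between measured compounds, a step that the limit leaves unreadable from compound 1 to compound 3, cannot be read in size because of the limit of > 2000 nM in this assay, at which 2 of the 3 values shown sit, so nothing measured tells how large a change at the saturated ring carbon can be in this assay.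

Compound 4 `O=C1CC(c2ncco2)CN1c1cnn2c1CN(C(=O)Nc1cc(F)c(F)c(F)c1)C(C1CC1)C2` is not yet measured. It differs from compound 1 in one place: 1,3-oxazol-2-yl in place of phenyl on a saturated ring carbon. Among the compounds with values here, no measured step touches this position, so the expectation for compound 4 rests on compound 1 alone. The step of a 1.1-fold lower number from compound 1 to compound 4 (0.03 log units; within the scatter) is expected to stay within the usual scatter of this assay, with no direction claimed. Compound 4 is therefore estimated at 12000 nM in this assay, with a range from 4000 nM to 35000 nM, and a fair chance that only a limit is reported, as for compound 2 and compound 3.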

Compound 4, half-maximal cytotoxic concentration: > 200000 nM
Compound 4 was reported as a limit; the forecaster's own chance of this, stated with the estimate: 45%; middle value at least 16-fold (1.22 log units) away from the limit.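

The position on the saturated ring carbon of the five-membered non-aromatic ring now has a readable step in this assay: 1,3-oxazol-2-yl in place of phenyl gives an at least 15-fold higher number from compound 1 to compound 4 (1.19 log units; beyond the scatter), in the direction of lower toxicity in this test, whereas compound 1, compound 2 and compound 3 all carry phenyl there and so say nothing about this place. The result for compound 4, > 200000 nM, is a limit of the assay and not a number. From the compounds shown here alone, the change at this carbon therefore counts as large, but only a lower bound on its size can be read, and its upper end stays open: the limit of > 200000 nM in this assay, at which 1 of the 4 values shown sits.

Open, going by these compounds, is whether the step follows the change from a six-membered to a five-membered aromatic ring or the hetero atoms, a question that pyridin-2-yl or thiophen-2-yl on the same carbon would separate. Also open, on these data alone, is whether the step holds with benzyl in place of cyclopropyl, as in compound 3, and the step from compound 1 to compound 3 still cannot be read.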